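From Methyl to Ethoxy on an Antiproliferative Compound

This account rests on a few compounds, and the source may have more. Where it says the series, first, only, none or still open, it means among the compounds named here.

Among the measured compounds shown here, only one compound in this small set gives a true number. In a functional assay on MCF7 cells (Homo sapiens) for antiproliferative activity, read by MTT assay, with a stated time of 72 h (on this read-out lower numbers stand for stronger inhibition and higher numbers for weaker inhibition), compound 1 `COc1cc(-n2ncnc2-c2ccc(C)cc2)cc(OC)c1OC` stands at 540 nM and so serves as the sole measured reference. Compound 2 `COc1cc(-c2ncnn2-c2ccc(Cl)cc2)cc(OC)c1OC` shows > 10000 nM as its result, and this is a limit of the assay rather than a number. Compound 3 `CCOc1cccc(-c2ncnn2-c2cc(OC)c(OC)c(OC)c2)c1` shows > 10000 nM as its result, which is likewise a limit.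

Compound 4 `CCOc1ccc(-c2ncnn2-c2cc(OC)c(OC)c(OC)c2)cc1` has not been measured yet. It keeps the core of compound 1 and alters one group. The change ethoxy in place of methyl on an aromatic carbon puts ethoxy in place of methyl on an aromatic carbon, para to a large group.

For the measured compounds named here, no measured pair in this assay isolates this swap, so any forecast rests on thin ground. Going by the values given here, the anchor is compound 1 at 540 nM because it is the only number available. Compound 3 also carries an ethoxy group and gave only a limit, so a large loss of activity cannot be ruled out, and the range must stay wide. The expected change a 1.4-fold lower number from compound 1 to compound 4 (0.13 log units; within the scatter) is small and lies within the scatter, with no firm direction. For compound 4 the estimated value in this assay is 400 nM with an expected range of 40 nM to 6000 nM on this read-out.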

Compound 4, half-maximal inhibitory concentration: 50 nM
Compound 4: the middle estimate sits 8.0-fold (0.90 log units) above what was measured; low and high end bracket the measured number.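

In this assay, placing ethoxy in place of methyl on an aromatic carbon, para to a large group, gives an 11-fold lower number from compound 1 to compound 4 (1.03 log units; beyond the scatter). Among the compounds shown here, because lower numbers mean stronger inhibition here, this large step, well beyond the usual scatter, shows that this position accepts the bigger ethoxy group and that the swap goes with a clear gain in activity, something the earlier compounds could not show, since they offered no step between two true numbers. Compound 3 also carries an ethoxy group, and its > 10000 nM is a limit of the assay and not a number, so the presence of ethoxy alone does not guarantee a low number in this set.

This single step cannot separate the part played by the added oxygen from that of the longer chain, and little else in the set can be compared as numbers: the limit of > 10000 nM in this assay, at which 2 of the 4 values shown sit.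

Still open, as far as these compounds go, is how a propoxy chain, a hydroxyl or an amine would behave at the same position, and whether the gain would continue, level off or reverse.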